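The source may hold more compounds than are shown below. What is called first, only, known or untested is meant among the compounds shown, and "the series" means these compounds.

Compound 1 `ClCc1cccc(Cn2cnc3ncnc(Cl)c32)c1`: 47900 nM
Compound 2 `ClCc1ccccc1Cn1cnc2ncnc(Cl)c21`: 5880 nM

In a functional assay on K562 cells (Homo sapiens) for cytotoxicity, read by sulforhodamine B assay, with a stated time of 48 h (on this read-out higher numbers stand for weaker inhibition of growth and lower numbers for stronger inhibition of growth), compound 2 gives 5880 nM, the lower of the two numbers available. Compound 1, its only comparator, gives 47900 nM in this assay, a higher figure that lies beyond the usual scatter, so compound 2 stands apart as the stronger grower inhibitor of the pair. The next compound, compound 3 `ClCc1ccccc1Cn1cnc2nc(Cl)nc(Cl)c21`, keeps the whole of compound 2 and differs from it in one place: chloro in place of hydrogen on an aromatic carbon. For the measured compounds named here, no measured pair shows what this particular change does, so the direction of the step cannot be read from the data at hand. Compound 3 is therefore expected to stay close to compound 2, with the step of a 1.5-fold lower number from compound 2 to compound 3 (0.17 log units; within the scatter) anticipated to be small and possibly within the scatter. The estimate for compound 3 is 4000 nM, with a range from 1200 nM to 15000 nM.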

Compound 3, concentration for total growth inhibition: 690 nM
The estimate for compound 3 lay 5.8-fold (0.76 log units) above the measured number, outside the stated range (below it).
By their numbers in this assay, from the lowest: compound 3; then compound 2; then compound 1.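

In this assay, chloro in place of hydrogen on the aromatic carbon between two ring nitrogen atoms gives a clear gain (an 8.5-fold lower number from compound 2 to compound 3 (0.93 log units; beyond the scatter)), moving the number toward stronger inhibition of growth. This shows that the position is not indifferent to substitution, something compounds 1 and 2, which both carry hydrogen there, could not show. No measurement given here explains why this change has such an effect.

With chloro as the only group shown at this carbon, it remains open whether an amine, a methoxy group or a methyl group would move the number in the same direction or by a similar amount. Going by these compounds, it also remains open whether the same change would give a comparable step on the core of compound 1.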